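Second chloro on the aryl ring of compound 1

The source may report more compounds than this note shows. Statements on the series, on what has been measured and on what is new or still open speak of the compounds shown alone.

Measured so far, in an assay on cells for inhibition of Palmitoleoyl-protein carboxylesterase NOTUM variant C330S (Homo sapiens), read by fluorescence, with a stated time of 40 min; a higher number here means a weaker inhibitor, a lower number a stronger inhibitor:
Compound 1 `Cc1cc(C(=O)O)c(C)n1-c1ccccc1Cl`: compound 1 gives 2300 nM
Compound 2 `Cc1cc(C(=O)O)c(C)n1-c1cc(Cl)ccc1Cl`: compound 2 gives 1700 nM

Among the compounds with values here, compound 1 has the highest number of the two, but its only neighbour is compound 2, and the step of a 1.4-fold lower number from compound 1 to compound 2 (0.13 log units; within the scatter) lies within the scatter, so the two are not separable on these data. Compound 3 `Cc1cc(C(=O)O)c(C)n1-c1c(Cl)cccc1Cl` keeps the core of compound 1 and differs by chloro in place of hydrogen on an aromatic carbon. Within the data shown here, the only measured step that bears on this change is the other chloro addition, a 1.4-fold lower number from compound 1 to compound 2 (0.13 log units; within the scatter), which was too small to read. Among the measured compounds shown here, no measured step addresses a chloro at this place. On that basis, compound 3 is expected to sit near compound 1, with a step in this assay of a 1.5-fold lower number from compound 1 to compound 3 (0.19 log units; within the scatter), which is not expected to exceed the scatter. The estimate for compound 3 is 1500 nM, in the range 500 nM to 4500 nM.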

Compound 3, half-maximal inhibitory concentration: 2300 nM
For compound 3 the middle estimate is 1.5-fold (0.19 log units) below the measured one; the range from low to high includes it.
By their numbers in this assay, from the lowest: compounds 2, 1 and 3 (each within the scatter of the next).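

In this assay, chloro in place of hydrogen on the aromatic carbon ortho to a large group and meta to a chloro group gives no change at the digits printed from compound 1 to compound 3 (within the scatter), so this position takes a second chloro with no readable effect on the number. The other chloro addition, a 1.4-fold lower number from compound 1 to compound 2 (0.13 log units; within the scatter), is also within the scatter, so neither of the two places tested separates a dichloro compound from compound 1. No supporting data bear on why the number holds at this position.

Still open, going by these compounds, is whether a group other than chloro at this position, such as methoxy, an amine or a nitrile, would move the number beyond the scatter. Also open, on these data alone, is how the series responds when the carboxylic acid of the shared core gives way to an amide or a tetrazole.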